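Pyrazole for pyridine on the benzylic aryl of compound 3

The source may hold more compounds than are shown below. What is called first, only, known or untested is meant among the compounds shown, and "the series" means these compounds.

Compound 1 `Cc1cc(C)c(NC(=O)N(Cc2ccc(N3CCN(C)CC3)cc2)C2CCCCCC2)c(C)c1` gives > 1 mg/kg in a functional assay on a cell-free system (plasma) with sterol O-acyltransferase, Soat (Rattus norvegicus) as the target (on this read-out higher numbers stand for an effect only at larger amounts of compound and lower numbers for an effect already at smaller amounts), a limit of the assay.
Compound 2 `Cc1cc(C)c(NC(=O)N(Cc2ccc(-c3cccs3)cc2)C2CCCCCC2)c(C)c1` gives 0.28 mg/kg in this assay.
Compound 3 `Cc1cc(C)c(NC(=O)N(Cc2ccc(-c3ccccn3)cc2)C2CCCCCC2)c(C)c1` gives > 1 mg/kg in this assay, a limit of the assay.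

Compound 3 thus sits at the limit rather than at a number, and it shares that position with compound 1 (the limit of > 1 mg/kg in this assay, at which 2 of the 3 values shown sit). Only compound 2 is resolved as a number, and the step of an at least 3.5-fold higher number from compound 2 to compound 3 (0.55 log units; beyond the scatter) shows that compound 3 is set apart from it. The step that the two limits leave unreadable from compound 1 to compound 3 cannot be read, since both ends are limits.

Compound 4 `Cc1cc(C)c(NC(=O)N(Cc2ccc(-c3cn[nH]c3)cc2)C2CCCCCC2)c(C)c1` differs from compound 3 in one place: 1H-pyrazol-4-yl in place of pyridin-2-yl on an aromatic carbon. Within the data shown here, no measured step swaps a pyridine for a pyrazole, so the bearing of the three steps is indirect. The step of an at least 3.5-fold lower number from compound 1 to compound 2 (0.55 log units; beyond the scatter) and the step of an at least 3.5-fold higher number from compound 2 to compound 3 (0.55 log units; beyond the scatter) show that, among these compounds, only the thiophen-2-yl group carries the read-out to a number, while the 4-methylpiperazin-1-yl and pyridin-2-yl groups both leave it at the limit.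

Compound 4 is therefore expected to stay near the limit, with the step that the limit leaves unreadable from compound 3 to compound 4 estimated as small. The estimate for compound 4 is 1.5 mg/kg, within a range from 0.4 mg/kg to 5 mg/kg.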

Compound 4, dose for half-maximal effect: > 1 mg/kg
Compound 4: a limit, no number; the forecaster's own chance of this, stated with the estimate: 55%; the middle value is on the limit's open side.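

With the 1H-pyrazol-4-yl group on an aromatic carbon para to a large group, the read-out in this assay stays at the limit, so a third group at this position leaves the result without a number: the limit of > 1 mg/kg in this assay, at which 3 of the 4 values shown sit.

The step of an at least 3.5-fold higher number from compound 2 to compound 4 (0.55 log units; beyond the scatter) shows that a five-membered aromatic ring at this place does not by itself bring a resolved value, since of the two such rings shown, only the thiophen-2-yl group does so. The steps that join the three compounds at the limit to one another cannot be read, since both ends of each are limits, and so the 1H-pyrazol-4-yl, pyridin-2-yl and 4-methylpiperazin-1-yl groups cannot be ordered among themselves.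

As far as these compounds go, how far each of these three compounds lies beyond the limit remains open, as a higher top dose would be needed to give them numbers. From the compounds shown here alone, it is also open whether the resolved value belongs to thiophen-2-yl alone or would extend to a plain phenyl ring, a furan-2-yl group or a thiophen-3-yl group at the same position.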